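A larger ring replaces bromine on the shared core

The source may report more compounds than this note shows. Statements on the series, on what has been measured and on what is new or still open speak of the compounds shown alone.

Compound 1 `CC(C(=O)NCc1ccc(C(F)(F)F)nc1Br)c1ccc(NS(C)(=O)=O)c(F)c1` stands highest of the three numbers measured in an assay on CHO cells for antagonist activity at transient receptor potential cation channel subfamily V member 1 (Homo sapiens), read by FLIPR and calcium flux (on this read-out lower numbers stand for stronger inhibition and higher numbers for weaker inhibition), giving 169 nM. Compound 2 `CC(C(=O)NCc1ccc(C(F)(F)F)nc1C1CCC(F)(F)CC1)c1ccc(NS(C)(=O)=O)c(F)c1` gives 1.5 nM and compound 3 `CC(C(=O)NCc1ccc(C(F)(F)F)nc1C1=CCCCC1)c1ccc(NS(C)(=O)=O)c(F)c1` gives 0.7 nM. The two steps away from compound 1 were both large: a 110-fold lower number from compound 1 to compound 2 (2.05 log units; beyond the scatter) and a 240-fold lower number from compound 1 to compound 3 (2.38 log units; beyond the scatter); between the two ring-bearing analogues the step was modest, a 2.1-fold lower number from compound 2 to compound 3 (0.33 log units; beyond the scatter).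

Compound 4 `CC1C=C(c2nc(C(F)(F)F)ccc2CNC(=O)C(C)c2ccc(NS(C)(=O)=O)c(F)c2)CCC1` differs from compound 1 as follows: 3-methylcyclohex-1-en-1-yl in place of bromo on an aromatic carbon. The step from compound 1 to compound 3 bears most directly on this change, since the entering group is again a cyclohexenyl ring carrying one extra methyl. A similarly large fall in the number is therefore expected, a 210-fold lower number from compound 1 to compound 4 (2.32 log units; beyond the scatter). Compound 4 is estimated at 0.8 nM, with a range from 0.3 nM to 2.5 nM.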

Compound 4, inhibition constant: 0.2 nM
Estimate against measurement, compound 4: 4.0-fold (0.60 log units) above, outside the stated range (below it).
By their numbers in this assay, from the lowest: compound 4; then compound 3; then compound 2; then compound 1.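

Adding methyl to the cyclohexenyl ring still moves the number (a 3.5-fold lower number from compound 3 to compound 4 (0.54 log units; beyond the scatter)), so this position responds to a small change on the ring itself, which the earlier compounds did not test. The 3-methylcyclohex-1-en-1-yl group gives the largest step yet away from bromo (an 850-fold lower number from compound 1 to compound 4 (2.93 log units; beyond the scatter)), and it also improves on 4,4-difluorocyclohexyl (a 7.5-fold lower number from compound 2 to compound 4 (0.88 log units; beyond the scatter)). Nothing measured here accounts for these steps. Open, on these data alone, is how an amine or hydroxyl group on that ring would read, and whether ethyl would extend the step seen with methyl.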